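The compounds below may be only part of what the source reports. "The series", "measured", "known", "first", "only" and "open" are said of these compounds alone.

In a functional assay on Jurkat cells (Homo sapiens) for cytotoxicity, read by luminescence and CellTiter-Glo, with a stated time of 3 days (on this read-out lower numbers stand for stronger inhibition and higher numbers for weaker inhibition), compound 3 (`O=C(Nc1ccc(C(F)(F)F)cc1)c1cc(Br)ccc1O`) gives 620 nM while compound 2 (`O=C(Nc1ccc(C(F)(F)F)cc1)c1cc(Br)c(F)cc1O`) gives 880 nM and compound 1 (`O=C(Nc1ccc(C(F)(F)F)cc1)c1cc(Cl)c(-c2ccccc2)cc1O`) gives 1160 nM in the same test, so compound 3 lies within the scatter of both. Compound 4 (`O=C(Nc1ccc(C(F)(F)F)cc1)c1cc(Br)c(-c2ccccc2)cc1O`) differs from compound 3 by one change (phenyl in place of hydrogen on an aromatic carbon), phenyl in place of hydrogen on an aromatic carbon. Within the data shown here, the single measured step, a 1.4-fold lower number from compound 2 to compound 3 (0.15 log units; within the scatter) for hydrogen in place of fluoro, is small but involves no phenyl. Compound 1 does carry phenyl, with chloro instead of bromo, and its 1160 nM is the closest guide. A small rise is therefore expected, not clearly beyond the scatter: a 1.6-fold higher number from compound 3 to compound 4 (0.21 log units; within the scatter) is the estimated step. Compound 4 is estimated at 1000 nM with 450 nM to 2200 nM as its expected span.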

Compound 4, half-maximal inhibitory concentration: 740 nM
For compound 4 the middle estimate is 1.4-fold (0.13 log units) above the measured one, and the stated range covers the measured number.
By their numbers in this assay, from the lowest: compounds 3, 4, 2 and 1 (each within the scatter of the next).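

Adding a phenyl at this aromatic carbon, para to a large group, moves the number little in this assay, with a 1.2-fold higher number from compound 3 to compound 4 (0.08 log units; within the scatter) and, for phenyl in place of fluoro, a 1.2-fold lower number from compound 2 to compound 4 (0.08 log units; within the scatter), so a group of this size leaves the read-out within the scatter. With the phenyl present, bromo in place of chloro also stays within the scatter, at a 1.6-fold lower number from compound 1 to compound 4 (0.20 log units; within the scatter) for that pair. Nothing measured here explains why these steps are small. The compounds shown leave open how an amine or a carboxylic acid at this carbon would behave, and whether a longer chain would keep the number in the same range.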